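The source may hold more compounds than are shown below. What is called first, only, known or untested is meant among the compounds shown, and "the series" means these compounds.

Three thiourea compounds have been tested so far, and a fourth awaits testing. Compound 1 `S=C(Nc1ccc(Cl)cc1)Nc1nc2ccccc2s1` is the starting point. In a functional assay on B16-F10 cells (Mus musculus) for cytotoxicity, read by MTT assay, with a stated time of 48 h (a lower number here means a stronger inhibitor, a higher number a weaker inhibitor), compound 1 reaches only a limit of the assay, > 50000 nM. Compound 2 `Fc1ccc(NC(=S)Nc2nc3ccccc3s2)cc1` differs from compound 1 by fluoro in place of chloro on an aromatic carbon. In this assay compound 2 likewise gives only a limit, > 50000 nM. Both values rest at the limit of > 50000 nM in this assay, at which 2 of the 3 values shown sit, so the step is a step that the two limits leave unreadable from compound 1 to compound 2.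

Compound 3 `Fc1ccc2nc(NC(=S)Nc3ccc(Cl)cc3)sc2c1` has a different core from compound 1, the difference being (fluoro in place of hydrogen on an aromatic carbon). In this assay, among the compounds with values here, compound 3 gives 48100 nM, the only plain number among the three, and the step is an at least 1.0-fold lower number from compound 1 to compound 3 (0.01 log units; that floor lies within the scatter), which says nothing firm about the core change.

Within the data shown here, compound 4 `Fc1ccc(NC(=S)Nc2nc3ccc(F)cc3s2)cc1` is the partner of compound 3 in the same way that compound 2 is the partner of compound 1: the change is fluoro in place of chloro on an aromatic carbon, the same change as the one between compound 1 and compound 2, made at the same kind of place. That earlier change could not be read because both of its compounds sit at the limit. Compound 4 is therefore expected to land near the same ceiling, and its estimated value in this assay is 55000 nM, expected to fall between 30000 nM and 100000 nM. The expected step is a 1.1-fold higher number from compound 3 to compound 4 (0.06 log units; within the scatter), since compound 3 stands at 48100 nM and the matching step that the two limits leave unreadable from compound 1 to compound 2 gives no direction.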

Compound 4, half-maximal inhibitory concentration: 47700 nM
Beside the measured number, compound 4's estimate is 1.2-fold (0.06 log units) above it; measured number inside the range.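

Swapping chloro for fluoro on the core of compound 3 gives a 1.0-fold lower number from compound 3 to compound 4 (0.00 log units; within the scatter) in this assay, so on this core the 4-chlorophenyl and 4-fluorophenyl compounds cannot be told apart. The matching step on the core of compound 1 cannot be read, because compound 1 and compound 2 both give only a limit, not a number: the limit of > 50000 nM in this assay, at which 2 of the 4 values shown sit. Fluoro in place of hydrogen on an aromatic carbon gives an at least 1.0-fold lower number from compound 2 to compound 4 (0.02 log units; that floor lies within the scatter), so these compounds do not show whether either change carries from one core to another, or whether it behaves differently on each core: the same change on two cores in this assay, an at least 1.0-fold lower number (0.01 log units; that floor lies within the scatter) from compound 1 to compound 3 and an at least 1.0-fold lower number (0.02 log units; that floor lies within the scatter) from compound 2 to compound 4; the limit leaves it open whether they differ.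

As far as these compounds go, all four compounds carry only chloro, fluoro or hydrogen at the places that change, so it remains open whether an amine or a carboxylic acid in place of the halogen on the phenyl ring would give a number clearly lower than these in this assay. From the compounds shown here alone, it is equally open what a urea in place of the thiourea, or a longer chain on the thiourea nitrogen, would do to that number.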